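Chain variation at the amine nitrogen of the shared core

The source may hold more compounds than are shown below. What is called first, only, known or untested is meant among the compounds shown, and "the series" means these compounds.

Compound 1 `Cc1ccc(-c2cnc(N(Cc3ccc(C(=O)NO)cc3)CC(C)C)s2)cc1` is examined in a functional assay on PC-3 cells (Homo sapiens) for antiproliferative activity, read by MTT assay, with a stated time of 48 h (a higher number here means a weaker inhibitor of growth, a lower number a stronger inhibitor of growth), where compound 1 gives 9340 nM, the second highest of the three numbers recorded so far. Compound 2 `Cc1ccc(OCCCN(Cc2ccc(C(=O)NO)cc2)c2ncc(-c3ccc(C)cc3)s2)cc1` gives 9330 nM and compound 3 `Cc1ccc(-c2cnc(N(CCCOc3ccccc3)Cc3ccc(C(=O)NO)cc3)s2)cc1` gives 17500 nM; the step of a 1.9-fold higher number from compound 2 to compound 3 (0.27 log units; within the scatter) lies within the scatter. Compound 4 `CCCCCCCCN(Cc1ccc(C(=O)NO)cc1)c1ncc(-c2ccc(C)cc2)s1` differs from compound 1 by heptyl in place of isopropyl on a saturated chain carbon bound to a nitrogen on an aromatic ring. The two changes made at the same place, a 1.0-fold lower number from compound 1 to compound 2 (0.00 log units; within the scatter) and a 1.9-fold higher number from compound 1 to compound 3 (0.27 log units; within the scatter), bear on this step; both fall within the scatter, so no step beyond the scatter is expected for compound 4 either. Compound 4 is accordingly estimated at 9500 nM, with a range of 3500 nM to 26000 nM, an expected step of a 1.0-fold higher number from compound 1 to compound 4 (0.01 log units; within the scatter).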

Compound 4, concentration for 50% growth inhibition: 13300 nM
For compound 4 the middle estimate is 1.4-fold (0.15 log units) below the measured one; low and high end bracket the measured number.
By their numbers in this assay, from the lowest: compounds 2, 1, 4 and 3 (each within the scatter of the next).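

In this assay, the position accepts heptyl, a chain with no ring, with no step beyond the scatter (a 1.4-fold higher number from compound 1 to compound 4 (0.15 log units; within the scatter)). Pentyl in place of phenoxy (a 1.3-fold lower number from compound 3 to compound 4 (0.12 log units; within the scatter)) and pentyl in place of 4-methylphenoxy (a 1.4-fold higher number from compound 2 to compound 4 (0.15 log units; within the scatter)) also stay within the scatter, so among these compounds the terminal aromatic ring is not required to keep the number in this range. No evidence is available to explain this flat picture.

Going by these compounds, whether a chain ending in an amine or a carboxylic acid, or one longer than octyl, would move the number beyond the scatter remains open.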